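The compounds below may be only part of what the source reports. "The series", "measured", "known", "first", "only" and "open" are said of these compounds alone.

Measured compounds, cytotoxicity read-out:
compound 1 `Cc1ccc2cc(CN(Cc3ccc(F)cc3)Cc3ccc(C(C)(C)C)cc3)c(=O)[nH]c2c1`: > 33000 nM (a limit)
compound 2 `CCc1ccc(CN(Cc2ccc(F)cc2)Cc2cc3ccc(C)cc3[nH]c2=O)cc1`: > 33000 nM (a limit)
compound 3 `CCc1ccc2[nH]c(=O)c(CN(Cc3ccc(C(C)(C)C)cc3)Cc3ccc(F)c(F)c3)cc2c1`: > 33000 nM (a limit)

In a toxicity assay on MDCK cells (Canis lupus familiaris) for cytotoxicity, read by crystal violet staining, with a stated time of 48 h (on this read-out lower numbers stand for higher toxicity in this test and higher numbers for lower toxicity in this test), compound 2 gives > 33000 nM, which is a limit of the assay and not a number. Compound 1 likewise gives > 33000 nM, a limit. Compound 3 gives > 33000 nM, also a limit. Going by the values given here, every value shown therefore sits at the limit of > 33000 nM in this assay, at which 3 of the 3 values shown sit, and the only step between measured compounds, a step that the two limits leave unreadable from compound 1 to compound 2, cannot be read in size. Compound 2 thus stands at the limit of this assay together with the other two measured compounds; nothing in the numbers separates any of them.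

Compound 4 `Cc1ccc2cc(CNCc3ccc(F)cc3)c(=O)[nH]c2c1` has not been measured in this assay. It differs from compound 2 by hydrogen in place of 4-ethylbenzyl on an amine nitrogen. Among the compounds with values here, no measured step bears on this change: the one step available concerns an ethyl in place of tert-butyl on an aromatic carbon, and it is unreadable. The expectation rests only on all three measured compounds sitting at the limit. The step expected for compound 4 is a step that the limit leaves unreadable from compound 2 to compound 4, none beyond the usual scatter, and most likely the assay will again return only a limit. For compound 4 the estimate is 50000 nM, with a range from 20000 nM to 150000 nM.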

Compound 4, half-maximal cytotoxic concentration: > 33000 nM
Compound 4 gave a limit, no number; the forecaster's own chance of this, stated with the estimate: 85%; the middle value is on the limit's open side.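

No new step can be read: compound 4 also returns only a limit in this assay, so the steps linking compound 1 and compound 2 to compound 4 stay unreadable in size: the limit of > 33000 nM in this assay, at which 4 of the 4 values shown sit.

The compounds shown leave open whether any of these changes on the amine nitrogen or aromatic carbon shifts the half-maximal cytotoxic concentration at all.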